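A Methoxy for a Methyl on the Shared Core

The compounds below may be only part of what the source reports. "The series", "measured", "known", "first", "only" and "open" are said of these compounds alone.

Of the compounds shown here, three of one series have been measured in a physicochemical assay for solubility, read by HPLC, in phosphate buffer, with a stated time of 24 h, at pH 7.4; a higher number here means a more soluble compound, a lower number a less soluble compound. Compound 1 `CCCS(=O)(=O)Nc1ccc(Cl)c(C(=O)Nc2cnc3[nH]nc(OC)c3c2)c1F` gives 2 ug/mL, and compound 3 `CCCS(=O)(=O)Nc1ccc(Cl)c(C(=O)Nc2cnc3[nH]ncc3c2)c1F` gives 48 ug/mL. Compound 2 `CCCS(=O)(=O)Nc1ccc(F)c(C(=O)Nc2cnc3[nH]nc(C)c3c2)c1F` gives 740 ug/mL, the highest of the three numbers, which lies well beyond the scatter above both others. Compound 4 `CCCS(=O)(=O)Nc1ccc(F)c(C(=O)Nc2cnc3[nH]nc(OC)c3c2)c1F` has not yet been measured. It differs from compound 2 in one place: methoxy in place of methyl on an aromatic carbon. For the measured compounds named here, no measured pair shows exactly this exchange, but one step bears on it: a 24-fold higher number from compound 1 to compound 3 (1.38 log units; beyond the scatter). Read in reverse, putting a methoxy onto that carbon of the shared core went with a large drop. Compound 2 and compound 3 differ in two places at once, so their values alone cannot separate the two exchanges. A sizable fall in this assay is therefore expected, estimated as a 19-fold lower number from compound 2 to compound 4 (1.27 log units; beyond the scatter). Compound 4 is expected to give about 40 ug/mL, with a likely range from 5 ug/mL to 300 ug/mL.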

Compound 4, solubility: 9 ug/mL
Estimate against measurement, compound 4: 4.4-fold (0.65 log units) above; the range from low to high includes it.
By their numbers in this assay, from the lowest: compound 1; then compound 4; then compound 3; then compound 2.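

Compound 2 and compound 4 now give a direct reading of methoxy in place of methyl on this aromatic carbon of the shared core: in this assay there is an 82-fold lower number from compound 2 to compound 4 (1.91 log units; beyond the scatter), a large step. With methoxy held in place, the other change, fluoro in place of chloro, gives a 4.5-fold higher number from compound 1 to compound 4 (0.65 log units; beyond the scatter), a modest step that is still beyond the usual scatter but much smaller than the exchange of methyl for methoxy. Nothing available explains either step.

Still open, from the compounds shown here alone, is how an amine or a longer chain such as ethoxy on this same carbon would read in this assay. Going by these compounds, it also remains open whether the exchange of methyl for methoxy would give a step of similar size with chloro in place of fluoro.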